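This account rests on a few compounds, and the source may have more. Where it says the series, first, only, none or still open, it means among the compounds named here.

Measured in an ADME assay (liver) for metabolic stability, with Liver microsome (Homo sapiens) as the target, read by LC-MS, using microsomes and NADPH, with a stated time of 5 min, at 37 degrees C; a lower number here means slower removal, a higher number faster removal of the compound:

- Compound 1 `CCn1c([C@@H](C)NS(=O)(=O)c2ccc(Cl)cc2)nc2ccc(C(F)(F)F)cc21`: > 100 mL.min-1.g-1 (a limit)
- Compound 2 `CCn1ncc(S(=O)(=O)N[C@H](C)c2nc3ccc(C(F)(F)F)cc3n2CC)c1C`: > 100 mL.min-1.g-1 (a limit)

Compound 2 stands at the limit of > 100 mL.min-1.g-1 in this assay, at which 2 of the 2 values shown sit, and so offers a limit and not a number. Compound 3 `CCn1c([C@@H](C)NS(=O)(=O)c2cn(C)c(C)n2)nc2ccc(C(F)(F)F)cc21` carries 1,2-dimethyl-1H-imidazol-4-yl in place of 1-ethyl-5-methyl-1H-pyrazol-4-yl on a sulfonyl sulfur. Within the data shown here, one measured step bears on this place, a step that the two limits leave unreadable from compound 1 to compound 2, and it gives no size to carry over. No direction can be read from it, so no step beyond the scatter is expected in this assay. The expected change is an at least 1.1-fold lower number from compound 2 to compound 3 (0.04 log units; that floor lies within the scatter) and it rests on a limit alone. Compound 3 is estimated at 90 mL.min-1.g-1 with an expected range from 35 mL.min-1.g-1 to 200 mL.min-1.g-1 and a fair chance of another limit.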

Compound 3, intrinsic clearance in microsomes: 43 mL.min-1.g-1
Beside the measured number, compound 3's estimate is 2.1-fold (0.32 log units) above it; measured number inside the range.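

In this assay, the group on the sulfonyl sulfur can shift the read-out: 1,2-dimethyl-1H-imidazol-4-yl gives an at least 2.3-fold lower number from compound 2 to compound 3 (0.36 log units; beyond the scatter) against 1-ethyl-5-methyl-1H-pyrazol-4-yl, and an at least 2.3-fold lower number from compound 1 to compound 3 (0.36 log units; beyond the scatter) against 4-chlorophenyl. The step between compound 1 and compound 2 cannot be read, so only compound 3 shows that this place matters, and even a change between two five-membered aromatic rings with 2 hetero atoms is enough to produce a step beyond the scatter. Both readable steps are floors and their full size stays unknown because the starting compounds sit at a limit: the limit of > 100 mL.min-1.g-1 in this assay, at which 2 of the 3 values shown sit.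

The compounds shown do not separate the arrangement of the ring nitrogens from the alkyl groups on the ring. Going by these compounds, how a longer chain or an amine in place of one methyl of 1,2-dimethyl-1H-imidazol-4-yl would read remains open.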